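A few compounds are considered here, and "the series" means these few. Any claim that something is new, unique, unknown or untested is made for them only; others in the source may bear on it.

Working notes on the series.

Three compounds carry the shared core with a long ether-linked chain ending in a quaternary ammonium group. Compound 1 `CC[N+]1(CCCCCCCOc2cc(C)cc(-n3cc(C(=O)Nc4cc(F)cc(F)c4)c(=O)c4ccc(N(C)C)nc43)c2)CCCC1` and compound 2 `CC[N+]1(CCCCCCCOc2cc(-n3cc(C(=O)Nc4cc(F)cc(F)c4)c(=O)c4ccc(N(C)C)nc43)ccc2C)CCCC1` have the same atoms joined differently; the difference between the two cores is not broken down here. In an assay on LX2 cells for inhibition of COL1A1 promoter (Homo sapiens), read by a luciferase reporter, with a stated time of 24 h, tested at 20 uM (a lower number here means a weaker effect, a higher number a stronger effect of the compound at the concentration tested), compound 1 gives 35.1% and compound 2 gives 57%, a gap beyond the usual scatter. Compound 3 `Cc1cc(OCCCCCCC[N+](C)(C)C2CCCCC2)cc(-n2cc(C(=O)Nc3cc(F)cc(F)c3)c(=O)c3ccc(N(C)C)nc32)c1` differs from compound 1 only at the chain end: a group of 9 heavy atoms (8 carbon, 1 nitrogen; one six-membered non-aromatic ring of carbon only) in place of a group of 7 heavy atoms (6 carbon, 1 nitrogen; one five-membered non-aromatic ring with 1 hetero atom), on a saturated chain carbon, seven bonds along the chain from an oxygen on an aromatic ring. This step, a number 17.4 percentage points higher from compound 1 to compound 3 (beyond the scatter), brings compound 3 to 52.5% in this assay. The values of compound 2 and compound 3 lie within the scatter of each other, so no order is read between them.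

Compound 4 `Cc1ccc(-n2cc(C(=O)Nc3cc(F)cc(F)c3)c(=O)c3ccc(N(C)C)nc32)cc1OCCCCCCC[N+](C)(C)C1CCCCC1` has not been measured. It stands to compound 2 as compound 3 stands to compound 1, the same change at the same place: a group of 9 heavy atoms (8 carbon, 1 nitrogen; one six-membered non-aromatic ring of carbon only) in place of a group of 7 heavy atoms (6 carbon, 1 nitrogen; one five-membered non-aromatic ring with 1 hetero atom), on a saturated chain carbon, seven bonds along the chain from an oxygen on an aromatic ring. The step is expected to be of the same sign, a number 11 percentage points higher from compound 2 to compound 4 (beyond the scatter), though somewhat smaller than a number 17.4 percentage points higher from compound 1 to compound 3 (beyond the scatter), because compound 2 already starts from 57%, a higher starting point than that of compound 1. On that basis compound 4 is expected to give 68% in this assay, with the range 52% to 82% allowing for the scatter and for the step not transferring fully onto the core of compound 2.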

Compound 4, a percentage reported as inhibition, at one concentration (the size of the read-out at that concentration, not a potency): 32.3%
For compound 4 the middle estimate is 35.7 percentage points above the measured one; measured number below the stated range.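

Carried onto the other core, the same change at the chain end gives a number 24.7 percentage points lower from compound 2 to compound 4 (beyond the scatter) in this assay. The change therefore does not transfer from one core to the other in this series, and the two steps differ in sign as well as in number: the same change on two cores in this assay, a number 17.4 percentage points higher (beyond the scatter) from compound 1 to compound 3 and a number 24.7 percentage points lower (beyond the scatter) from compound 2 to compound 4, 42.1 percentage points apart, beyond the scatter of two such steps What this does not show is why the two cores respond differently, or whether the reversal is general: it rests on one pair of compounds on each core, read at a single concentration, and these data assign no cause to either group or to the difference in the cores.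

The compounds shown leave open whether the opposite steps are particular to this pair of chain-end groups or would also appear with other ends on the same chain, such as a trimethylammonium group, a piperidinium ring or an uncharged tertiary amine. They also leave open whether the same reversal would be seen with a shorter or a longer chain carrying these two groups on both cores, so for now the effect of a chain-end change is best read separately for each core.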